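Replacing a urea linker on a bicyclic sultone nucleoside

A few compounds are considered here, and "the series" means these few. Any claim that something is new, unique, unknown or untested is made for them only; others in the source may bear on it.

Measured so far:
- compound 1, `CCNC(=O)NC1=CS(=O)(=O)O[C@@]12[C@@H](CO[Si](C)(C)C(C)(C)C)O[C@@H](n1cc(C)c(=O)n(C)c1=O)[C@@H]2O[Si](C)(C)C(C)(C)C`: 4260 nM
- compound 2, `CCOC(=O)CNC(=O)NC1=CS(=O)(=O)O[C@@]12[C@@H](CO[Si](C)(C)C(C)(C)C)O[C@@H](n1cc(C)c(=O)n(C)c1=O)[C@@H]2O[Si](C)(C)C(C)(C)C`: 5020 nM

Both compounds share the same core and were tested in a functional assay on CCRF-CEM cells (Homo sapiens); a higher number here means that more compound is tolerated, a lower number that less compound is tolerated. Compound 2 gives the higher of the two numbers, though its nearest neighbour, compound 1, lies within the scatter of it: the step of a 1.2-fold higher number from compound 1 to compound 2 (0.07 log units; within the scatter) tells nothing beyond noise. That step, an exchange of ethoxycarbonyl for methyl on the chain carbon, is the only one available.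

Compound 3, `Cc1cn([C@@H]2O[C@H](CO[Si](C)(C)C(C)(C)C)[C@@]3(OS(=O)(=O)C=C3NCC(=O)C(N)=O)[C@H]2O[Si](C)(C)C(C)(C)C)c(=O)n(C)c1=O`, has not yet been measured. It differs from compound 2 by (carbamoylcarbonyl)methyl in place of ((ethoxycarbonyl)methyl)carbamoyl on an amine nitrogen. For the measured compounds named here, this is a larger change than the one between compound 1 and compound 2, as the carbamoyl link is removed and the side chain is shortened, so the single measured step bears on it only loosely. Going by the values given here, since the one known step, a 1.2-fold higher number from compound 1 to compound 2 (0.07 log units; within the scatter), stayed within the scatter, no direction is indicated, and compound 3 is expected to land near compound 2 with a wide range.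

Compound 3 is estimated at 4500 nM (range 1500 nM to 14000 nM), which corresponds to an expected step of a 1.1-fold lower number from compound 2 to compound 3 (0.05 log units; within the scatter).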

Compound 3, half-maximal cytotoxic concentration: 9960 nM
Compound 3: the middle estimate sits 2.2-fold (0.35 log units) below what was measured, and the stated range covers the measured number.
By their numbers in this assay, from the lowest: compounds 1, 2 and 3 (each within the scatter of the next, the first and the last beyond it).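

On the amine nitrogen, (carbamoylcarbonyl)methyl in place of ((ethoxycarbonyl)methyl)carbamoyl gives in this assay a 2.0-fold higher number from compound 2 to compound 3 (0.30 log units; within the scatter) and so leaves the number within the scatter, even though this is a much larger change than the earlier exchange on the chain carbon and removes the carbamoyl link from that nitrogen. For the compounds shown here, measured against the ethylcarbamoyl group of compound 1, the same group gives a 2.3-fold higher number from compound 1 to compound 3 (0.37 log units; beyond the scatter) and thereby provides the first step in this set that clears the scatter, a modest one towards more compound being tolerated. Nothing available here explains this difference.

The three compounds do not separate what the loss of the carbamoyl link contributes from what the carbamoylcarbonyl group itself contributes, since both differ together in compound 3. As far as these compounds go, it also remains open how a plain ethyl group on the same amine nitrogen, or a carboxylic acid in place of the primary amide of the carbamoylcarbonyl group, would read in this assay and whether either would extend this modest step.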